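Amide-nitrogen substituents in the shared core: outlook for compound 4

The compounds below may be only part of what the source reports. "The series", "measured", "known", "first", "only" and "open" are said of these compounds alone.

Measured in a functional assay on HEK293 cells for positive allosteric modulation of metabotropic glutamate receptor 5 (Rattus norvegicus), read by fluorescence and calcium flux; a higher number here means a larger maximal response, a lower number a smaller maximal response:
Compound 1 `C[C@@H](NC(=O)c1ccc(C#Cc2cccc(F)c2)cn1)C(C)(C)C` gives 66%.
Compound 2 `CC(C)[C@@H](C)NC(=O)c1ccc(C#Cc2cccc(F)c2)cn1` gives 69.3%.
Compound 3 `O=C(NCC1CC1)c1ccc(C#Cc2cccc(F)c2)cn1` gives 61.4%.

Compound 3 has the lowest of the three numbers, but the steps to it, a number 4.6 percentage points lower from compound 1 to compound 3 (within the scatter) and a number 7.9 percentage points lower from compound 2 to compound 3 (within the scatter), are both within the scatter, so no order among the three can be read from them. Within the data shown here, the one step that does not touch the amide-type nitrogen, a number 3.3 percentage points higher from compound 1 to compound 2 (within the scatter), is likewise within the scatter.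

Compound 4 `CC1(CCNC(=O)c2ccc(C#Cc3cccc(F)c3)cn2)COC1` differs from compound 3 in one place: (3-methyloxetan-3-yl)methyl in place of cyclopropyl on a saturated chain carbon bound to an amide-type nitrogen. Among the measured compounds shown here, the steps that bear on this change are the two that also exchange the group on the amide-type nitrogen, from compound 1 and from compound 2 to compound 3; each stayed within the scatter, with no direction shared between them. For the measured compounds named here, nothing measured so far separates one amide-nitrogen substituent from another in this assay, and an oxygen-containing ring in this position has not been tested.

The expected step is therefore a number 0.6 percentage points higher from compound 3 to compound 4 (within the scatter), none beyond the scatter. The estimate for compound 4 in this assay is 62%, within 50% to 74%.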

Compound 4, largest response reached (reported as efficacy), in percent of the reference or control that the assay uses: 65.7%
The estimate for compound 4 lay 3.7 percentage points below the measured number; measured number inside the range.
By their numbers in this assay, from the lowest: compounds 3, 4, 1 and 2 (each within the scatter of the next).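

In this assay, an oxygen-containing ring at this position, (3-methyloxetan-3-yl)methyl in place of cyclopropyl on a saturated chain carbon bound to an amide-type nitrogen, gives a step that stays inside the scatter (a number 4.3 percentage points higher from compound 3 to compound 4 (within the scatter)). Set against the two branched groups on the amide-type nitrogen, 2-(3-methyloxetan-3-yl)ethyl also cannot be told apart (a number 3.6 percentage points lower from compound 2 to compound 4 (within the scatter); a number 0.3 percentage points lower from compound 1 to compound 4 (within the scatter)), so a substituent carrying one hydrogen-bond acceptor fits within the same band of maximal response as the substituents made of carbon alone. No accompanying measurement bears on why these steps are small.

From the compounds shown here alone, whether any group on the amide-type nitrogen can move the maximal response beyond the scatter remains open. A basic amine, a carboxylic acid or a longer chain at this position would test that.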